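A thiourea in place of the cyanoguanidine on the chain

The compounds below may be only part of what the source reports. "The series", "measured", "known", "first", "only" and "open" are said of these compounds alone.

Compound 2 `CCC/N=C(/NC#N)NCCCCCn1nc(-c2ccccc2)ccc1=O` has been tested in a functional assay on the whole organism with Rattus norvegicus as the target, at a dose of 100 mg/kg (a higher number here means more inhibition at the dose given (going by the name of the read-out), a lower number less inhibition), where compound 2 gives 27.5%. Among the compounds with values here, of the three numbers measured so far this is the second highest. The nearest is compound 1 `N#CNC(=N)NCCCCCn1nc(-c2ccccc2)ccc1=O`, which in this assay gives 31%; the furthest is compound 3 `O=c1ccc(-c2ccccc2)nn1CCCNC(=S)NC1CCCCC1`, which in this assay gives 23.6%. Both gaps from compound 2 lie within the scatter of repeated measurements, so no order among the three can be read from them.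

Compound 4 `C/N=C(\S)NCCCCCCn1nc(-c2ccccc2)ccc1=O` has not yet been measured. It differs from compound 2 in one place: a group of 6 heavy atoms (3 carbon, 2 nitrogen, 1 sulfur; no ring) in place of a group of 9 heavy atoms (5 carbon, 4 nitrogen; no ring), on a saturated chain carbon, five bonds along the chain from an aromatic nitrogen.

Within the data shown here, only one measured step changes a single place, and it is a number 3.5 percentage points lower from compound 1 to compound 2 (within the scatter), which alters the substituent on the amine nitrogen rather than the group that is exchanged here. Compound 3 also carries a sulfur-bearing group on its chain, but it differs from compound 2 in more than one place, so only its value can be compared, and that value sits within the scatter of compound 2. Among the measured compounds shown here, nothing among the measured compounds therefore points to a step beyond the scatter.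

Compound 4 is accordingly expected to give about 25% in this assay, estimated between 12% and 40%. The step this estimate implies, a number 2.5 percentage points lower from compound 2 to compound 4 (within the scatter), is expected to stay within the scatter.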

Compound 4, a percentage reported as inhibition, in the whole organism at one dose (the size of the read-out at that dose, not a potency): 22.2%
Beside the measured number, compound 4's estimate is 2.8 percentage points above it, and the stated range covers the measured number.
By their numbers in this assay, from the lowest: compounds 4, 3, 2 and 1 (each within the scatter of the next).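

Within the data shown here, at this position, on a saturated chain carbon, five bonds along the chain from an aromatic nitrogen, the earlier compounds gave no single-place exchange of the whole end group, and compound 4 now provides two such comparisons in this assay: a number 5.3 percentage points lower from compound 2 to compound 4 (within the scatter) and a number 8.8 percentage points lower from compound 1 to compound 4 (within the scatter). Both steps remain within the scatter, so the group of 6 heavy atoms with its sulfur can stand in place of either nitrogen-rich group without a difference that this assay can separate from repeat variation, whether the group it replaces has 9 heavy atoms or 6. The same holds although the group leaving compound 2 has a triple bond and the one entering does not, and nothing available offers an explanation for these results.

The compounds shown leave open whether any end group at this position can move the number beyond the scatter, since all of these exchanges keep a chain-end group of the same broad kind. A primary amine or a carboxylic acid in this place would test that more sharply, and whether the small steps seen here would persist at another dose also remains unsettled.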